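Sulfation in a glucosamine-derived series: one step, one expectation

The source may report more compounds than this note shows. Statements on the series, on what has been measured and on what is new or still open speak of the compounds shown alone.

Measured compounds in a functional assay on U-373MG ATCC cells (Homo sapiens), read by thymidine incorporation; on this read-out higher numbers stand for weaker inhibition and lower numbers for stronger inhibition:
Compound 1, `C=CCCC(=O)N[C@H]1[C@@H](OCCc2ccccc2)O[C@H](CO)[C@@H](O)[C@@H]1O`, gives > 50 uM; this is a limit of the assay, not a number.
Compound 2, `CCCCC(=O)N[C@H]1[C@@H](OCCc2ccccc2)O[C@H](COCC(CO)(CO)COS(=O)(=O)O)[C@@H](O)[C@@H]1O`, gives 6.7 uM.
Compound 3, `CCCCC(=O)N[C@H]1[C@@H](OCCc2ccccc2)O[C@H](COCC(CO)(CO)CO)[C@@H](O)[C@@H]1O`, gives > 50 uM; this too is a limit, not a number.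

Among the compounds with values here, the one measured step is the change (sulfo in place of hydrogen on an oxygen on a saturated carbon), which produced an at least 7.4-fold lower number from compound 3 to compound 2 (0.87 log units; beyond the scatter). The lower end of that step is fixed by the limit of > 50 uM in this assay, at which 2 of the 3 values shown sit, so its true size is open upward.

Compound 4, `C=CCCC(=O)N[C@H]1[C@@H](OCCc2ccccc2)O[C@H](CO)[C@@H](O)[C@@H]1OS(=O)(=O)O`, is not yet measured. It arises from compound 1 by sulfo in place of hydrogen on an oxygen on a saturated carbon. This is the same kind of change as that from compound 3 to compound 2, but not the same: in compound 4 the oxygen sits on a saturated carbon whose other neighbour is a saturated ring carbon, whereas in compound 2 that neighbour is a saturated chain carbon. The difference between the two cores is not broken down here.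

Resting only on the step from compound 3 to compound 2, compound 4 is expected to show an at least 3.3-fold lower number from compound 1 to compound 4 (0.52 log units; beyond the scatter) in this assay, giving an estimated 15 uM, within about 4 uM to 50 uM.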

Compound 4, concentration for 50% inhibition: > 50 uM
Compound 4: no number, only a limit; the forecaster's own chance of this, stated with the estimate: 35%; middle value at least 3.3-fold (0.52 log units) away from the limit.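

Compound 1 and compound 4 both stop at a limit rather than a number, so no step can be read between them, because neither value can be placed against the other: the limit of > 50 uM in this assay, at which 3 of the 4 values shown sit. The compounds shown leave open whether sulfo in place of hydrogen on this oxygen changes inhibition in compound 4 at all, and in which direction.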